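Methylating the amine of compound 1: an expected small step

The source may report more compounds than this note shows. Statements on the series, on what has been measured and on what is new or still open speak of the compounds shown alone.

Measured compounds:
Compound 1 `CNCc1cc2cnccc2s1` gives 1500 nM in an assay on isolated protein for inhibition of cytochrome P450 2A6 (Homo sapiens), read by fluorescence, with a stated time of 10 min; on this read-out higher numbers stand for weaker inhibition and lower numbers for stronger inhibition.
Compound 2 `O=CCc1coc2ccccc12` reaches only a limit of the assay, < 100000 nM in this assay.
Compound 3 `NC(=S)c1csc2ccncc12` gives 6600 nM in this assay.

Compound 1 stands at the lowest of the two real numbers in this assay. The nearest is compound 3, whose number is higher by a gap that lies beyond the usual scatter of repeated measurements. The value of compound 2 is a limit and not a number, as the evidence the limit of < 100000 nM in this assay, at which 1 of the 3 values shown sits, shows, so it offers no comparison.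

Compound 4 `CN(C)Cc1cc2cnccc2s1` has not yet been measured. It differs from compound 1 by methyl in place of hydrogen on an amine nitrogen whose other neighbours are two saturated chain carbons: methylamino becomes dimethylamino. Among the compounds with values here, no pair of measured compounds shows this change, so its effect in this assay rests on expectation alone. A small step is expected, if any, leaning toward a somewhat higher number rather than a lower one, and possibly none beyond the scatter.

Compound 4 is therefore estimated at 2500 nM, within a range of 800 nM to 8000 nM. This estimate means an expected step of a 1.7-fold higher number from compound 1 to compound 4 (0.22 log units; within the scatter).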

Compound 4, half-maximal inhibitory concentration: 1400 nM
For compound 4 the middle estimate is 1.8-fold (0.25 log units) above the measured one, within the range that was stated.
By their numbers in this assay, from the lowest: compounds 4 and 1 (each within the scatter of the next); then compound 3.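

In this assay, within the data shown here, the exchange of hydrogen for methyl on this amine nitrogen gives a 1.1-fold lower number from compound 1 to compound 4 (0.03 log units; within the scatter), the first measured pair to show this change. The hydrogen on the nitrogen of the methylamino group can therefore give way to methyl, turning it into dimethylamino, with no change in inhibition that can be told from the scatter. No measured property shown here accounts for this outcome.

The compounds shown leave open whether a larger group on this nitrogen, such as an ethyl group or a longer chain, would be accommodated as well as methyl. They also leave open how the primary amine or an amide at this place would compare, and whether the same exchange would behave alike on another core.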